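Bromo in Place of Nitro on the Sulfonyl Phenyl Ring

This account rests on a few compounds, and the source may have more. Where it says the series, first, only, none or still open, it means among the compounds named here.

Compound 1 `N#CC1=C(NC(=S)Nc2ccc(Br)cc2)N(c2ccc(S(N)(=O)=O)cc2)C2=C(C(=O)CCC2)C1c1ccc(Cl)cc1Cl`: 25 ug/mL
Compound 2 `N#CC1=C(NC(=O)CCC(=O)O)N(c2ccc(S(N)(=O)=O)cc2)C2=C(C(=O)CCC2)C1c1ccc(Cl)cc1Cl`: 50 ug/mL
Compound 3 `N#CC1=C(NS(=O)(=O)c2ccc([N+](=O)[O-])cc2)N(c2ccc(S(N)(=O)=O)cc2)C2=C(C(=O)CCC2)C1c1ccc(Cl)cc1Cl`: 20 ug/mL

All three share one core and differ only in the group on the amine nitrogen. In a functional assay on Ehrlich cells (Mus musculus) for cytotoxicity, read by trypan blue exclusion, with a stated time of 2 h (on this read-out higher numbers stand for weaker inhibition and lower numbers for stronger inhibition), compound 3 gives the lowest number of the three, though the gap from compound 1, a 1.3-fold lower number from compound 1 to compound 3 (0.10 log units; within the scatter), is within the scatter, while a 2.5-fold lower number from compound 2 to compound 3 (0.40 log units; beyond the scatter) is a modest step beyond it. Compound 4 `N#CC1=C(NS(=O)(=O)c2ccc(Br)cc2)N(c2ccc(S(N)(=O)=O)cc2)C2=C(C(=O)CCC2)C1c1ccc(Cl)cc1Cl` keeps the sulfonyl phenyl group of compound 3 and changes one substituent: bromo in place of nitro on an aromatic carbon. Among the compounds with values here, no measured step alters only that substituent; the closest comparison, a 1.3-fold lower number from compound 1 to compound 3 (0.10 log units; within the scatter), replaces the whole group on the nitrogen and stays within the scatter. Compound 4 is therefore expected to land near compound 3, with a step of a 1.3-fold higher number from compound 3 to compound 4 (0.10 log units; within the scatter) in this assay. The estimate for compound 4 is 25 ug/mL, between 12 ug/mL and 50 ug/mL.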

Compound 4, half-maximal inhibitory concentration: 5.5 ug/mL
For compound 4 the middle estimate is 4.5-fold (0.66 log units) above the measured one; measured number below the stated range.
By their numbers in this assay, from the lowest: compound 4; then compounds 3, 1 and 2 (each within the scatter of the next, the first and the last beyond it).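

Bromo in place of nitro gives a 3.6-fold lower number from compound 3 to compound 4 (0.56 log units; beyond the scatter) in this assay, so this one substituent on the aromatic carbon changes the result, not only the kind of group on the amine nitrogen. The earlier compounds shown here did not separate beyond the scatter between compound 1 and compound 3, but a 4.5-fold lower number from compound 1 to compound 4 (0.66 log units; beyond the scatter) and a 9.1-fold lower number from compound 2 to compound 4 (0.96 log units; beyond the scatter) place compound 4 clearly lowest of the four. Nothing measured here explains the difference between bromo and nitro. As far as these compounds go, whether chloro, methoxy or an amine on this same carbon would give a number nearer that of bromo or of nitro remains open.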